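From Cyclopentylmethyl to 4-Fluorophenyl at the Assay Limit

The compounds below may be only part of what the source reports. "The series", "measured", "known", "first", "only" and "open" are said of these compounds alone.

Of the compounds shown here, three on one shared core have been read so far in an ADME assay on Huh-7 cells (Homo sapiens) for cytotoxicity, with a stated time of 72 h (on this read-out lower numbers stand for higher toxicity in this test and higher numbers for lower toxicity in this test), as their test. Compound 1 (`CC(C)(C)Cn1nc(-c2cccs2)c(O)c(C2=NS(=O)(=O)c3cc(NS(C)(=O)=O)ccc3N2)c1=O`) gives > 1000 nM as a limit of the assay and not a number. Compound 2 (`CS(=O)(=O)Nc1ccc2c(c1)S(=O)(=O)N=C(c1c(O)c(-c3cccs3)nn(CC3(C(F)(F)F)CCC3)c1=O)N2`) gives > 1000 nM as a limit too. Compound 3 (`CS(=O)(=O)Nc1ccc2c(c1)S(=O)(=O)N=C(c1c(O)c(-c3cccs3)nn(CCC3CCCC3)c1=O)N2`) gives > 1000 nM as a limit as well, so it has no number of its own. The whole record is the limit of > 1000 nM in this assay, at which 3 of the 3 values shown sit, and it holds no numerical reading.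

Compound 4 (`CS(=O)(=O)Nc1ccc2c(c1)S(=O)(=O)N=C(c1c(O)c(-c3cccs3)nn(Cc3ccc(F)cc3)c1=O)N2`) carries 4-fluorophenyl in place of cyclopentylmethyl on a saturated chain carbon bound to an aromatic nitrogen. The same difference, cut one bond further out, reads 2-cyclopentylethyl to 4-fluorobenzyl.

The measured steps at this place are a step that the two limits leave unreadable from compound 1 to compound 3 and a step that the two limits leave unreadable from compound 2 to compound 3 and a step that the two limits leave unreadable from compound 1 to compound 2 and they offer no size to carry over. With compound 3 at > 1000 nM as the starting limit, no step beyond the scatter is expected in this assay and no direction can be argued. The expected change is a step that the limit leaves unreadable from compound 3 to compound 4 as an estimate only. Compound 4 is estimated at 1500 nM with an expected range of 700 nM to 5000 nM and will most likely be reported as a limit again.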

Compound 4, half-maximal cytotoxic concentration: > 1000 nM
Compound 4: no number, only a limit; the forecaster's own chance of this, stated with the estimate: 85%; the middle value does not contradict the limit.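

In this assay compound 4 gives > 1000 nM, a limit of the assay and not a number. Its steps from compound 1, compound 2 and compound 3 cannot be read, as every value is a limit: the limit of > 1000 nM in this assay, at which 4 of the 4 values shown sit.

The compounds shown leave open how far these four differ in this assay, and whether any group at this place would give a numerical reading.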